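The source may hold more compounds than are shown below. What is called first, only, known or untested is meant among the compounds shown, and "the series" means these compounds.

The shared core appears in compound 1 `O=S(=O)(Nc1ccc2oc(-c3ccccc3)nc2c1)c1ccccc1Cl`, which carries a 2-chlorophenyl group on the sulfonyl sulfur. In an assay on cells for inhibition of HSP60/HSP10 (Homo sapiens), with a stated time of 60 min (on this read-out lower numbers stand for stronger inhibition and higher numbers for weaker inhibition), compound 1 gives only a limit, > 100000 nM, and no number. Compound 2 `O=S(=O)(Nc1ccc2oc(-c3ccccc3)nc2c1)c1cccc(O)c1` carries a 3-hydroxyphenyl group on the same sulfur, and in this assay compound 2 gives 76000 nM. Compound 3 `O=S(=O)(Nc1ccc2oc(-c3ccccc3)nc2c1)c1cccs1` carries a thiophen-2-yl group there, and in this assay compound 3 gives 90000 nM. All three values sit at the weak end of the range, and the measured steps are small: an at least 1.3-fold lower number from compound 1 to compound 2 (0.11 log units; that floor lies within the scatter), an at least 1.1-fold lower number from compound 1 to compound 3 (0.04 log units; that floor lies within the scatter), and a 1.2-fold higher number from compound 2 to compound 3 (0.07 log units; within the scatter). Compound 4 `O=S(=O)(Nc1ccc2oc(-c3ccccc3)nc2c1)c1ccccc1C(F)(F)F` differs from compound 1 by trifluoromethyl in place of chloro on an aromatic carbon. Among the measured compounds shown here, none of the measured steps touches the chloro group alone; each exchanges the whole ring on the sulfonyl sulfur, and each stayed within the scatter. The step of a number no higher from compound 1 to compound 4 (the limit leaves the size open) is therefore expected to be of the same order, with no direction beyond the scatter. For compound 4 the estimate in this assay is 100000 nM, with a range from 40000 nM to 250000 nM, and it is expected that this assay may again report only a limit for compound 4.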

Compound 4, half-maximal inhibitory concentration: > 100000 nM
Compound 4 ended at the assay's limit; the forecaster's own chance of this, stated with the estimate: 55%; the middle value lies on the limit itself.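

In this assay compound 4 gives > 100000 nM, which is a limit and not a number. Compound 1 also gives only a limit, so the step between compound 1 and compound 4 cannot be read: the limit of > 100000 nM in this assay, at which 2 of the 4 values shown sit. The compounds shown leave open whether trifluoromethyl in place of chloro changes the inhibition at all.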